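Indole-to-chlorophenyl swap on a hydrazone-urea series

This account rests on a few compounds, and the source may have more. Where it says the series, first, only, none or still open, it means among the compounds named here.

The measured compounds:
Compound 1 `CN(C)CCn1cnnc1-c1cc(Oc2ccc(NC(=O)N/N=C/c3c[nH]c4ccccc34)cc2F)ccn1` gives 790 nM in a functional assay on MKN-45 cells (Homo sapiens) for cytotoxicity, read by MTT assay, with a stated time of 72 h; on this read-out lower numbers stand for stronger inhibition and higher numbers for weaker inhibition.
Compound 2 `COc1ccc(/C=N/NC(=O)Nc2ccc(Oc3ccnc(-c4nncn4CCN(C)C)c3)c(F)c2)c(OC)c1OC` gives 2020 nM.
Compound 3 `CN(C)CCn1cnnc1-c1cc(Oc2ccc(NC(=O)N/N=C/c3ccccc3O[N+](=O)[O-])cc2F)ccn1` gives 1020 nM.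

Compound 1 stands at one end of these three numbers: compound 3 lies within the scatter of it a 1.3-fold higher number from compound 1 to compound 3 (0.11 log units; within the scatter), while the step to compound 2 is beyond it a 2.6-fold higher number from compound 1 to compound 2 (0.41 log units; beyond the scatter). Compound 4 `CN(C)CCn1cnnc1-c1cc(Oc2ccc(NC(=O)N/N=C/c3ccc(Cl)cc3)cc2F)ccn1` is not yet measured; it differs from compound 1 by 4-chlorophenyl in place of 1H-indol-3-yl on a carbon with a double bond to nitrogen. The two measured steps that replace the 1H-indol-3-yl group both gave higher numbers, one within and one beyond the scatter, and the step between those two replacements a 2.0-fold lower number from compound 2 to compound 3 (0.30 log units; within the scatter) stayed within it. A modest rise is therefore expected for compound 4, on the order of a 1.6-fold higher number from compound 1 to compound 4 (0.22 log units; within the scatter). Compound 4 is estimated at 1300 nM, with a range from 600 nM to 3000 nM.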

Compound 4, half-maximal inhibitory concentration: 570 nM
Estimate against measurement, compound 4: 2.3-fold (0.36 log units) above, outside the stated range (below it).
By their numbers in this assay, from the lowest: compounds 4, 1, 3 and 2 (each within the scatter of the next, the first and the last beyond it).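

On the carbon with a double bond to nitrogen, 4-chlorophenyl keeps the level of the 1H-indol-3-yl group (a 1.4-fold lower number from compound 1 to compound 4 (0.14 log units; within the scatter)), so the ring system and hydrogen-bond donor that leave are not needed to hold this level. The chlorinated compound also stays level with the nitrooxy compound (a 1.8-fold lower number from compound 3 to compound 4 (0.25 log units; within the scatter)), while the step from the trimethoxy compound lies beyond the scatter (a 3.5-fold lower number from compound 2 to compound 4 (0.55 log units; beyond the scatter)). No evidence given here bears on the reason for these results. The compounds shown leave open whether a cyclohexyl ring, a methyl group or an aminoethyl chain on this carbon would hold the same level.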